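The source may hold more compounds than are shown below. What is called first, only, known or untested is meant among the compounds shown, and "the series" means these compounds.

Measured compounds:
compound 1, `CCN(CC)CCCn1c(=O)c(=Cc2ccc(F)c(F)c2)s/c1=C1\C(=O)Nc2cc(F)ccc21`: 28 nM
compound 2, `CCN(CC)CCCn1c(=O)c(=Cc2ccc(F)cc2F)s/c1=C1\C(=O)Nc2ccccc21`: > 200000 nM

In a functional assay on HT-29 cells (Homo sapiens) for inhibition, read by MTT assay, with a stated time of 72 h (a lower number here means a stronger inhibitor, a higher number a weaker inhibitor), compound 1 gives 28 nM. For compound 2 the result in this assay is only a limit, > 200000 nM, so no number is known for it. Compound 2 thus stands at the limit of the measurement; (the limit of > 200000 nM in this assay, at which 1 of the 2 values shown sits).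

Compound 3, `CCN(CC)CCCn1c(=O)c(=Cc2ccc(F)cc2F)s/c1=C1\C(=O)Nc2cc(F)ccc21`, has not yet been measured in this assay. It differs from compound 2 in one place: fluoro in place of hydrogen on an aromatic carbon. For the measured compounds named here, the same fluoro on the fused ring is also present in compound 1, yet compound 1 and compound 2 differ in a second place as well, so no single measured step shows what this change alone does.

Because compound 1 carries this fluoro and gives 28 nM, an improvement is expected for compound 3. The size of that improvement is uncertain: compound 2 is known only as a limit. The step from compound 2 to compound 3 is expected to be an at least 40-fold lower number from compound 2 to compound 3 (1.60 log units; beyond the scatter), and compound 3 is estimated at 5000 nM, between 200 nM and 200000 nM.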

Compound 3, half-maximal inhibitory concentration: 1520 nM
Compound 3: the middle estimate sits 3.3-fold (0.52 log units) above what was measured; low and high end bracket the measured number.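

In this assay, the fluoro on the fused ring now has a measured effect of its own: with the 2,4-difluorophenyl held in place, the change gives an at least 130-fold lower number from compound 2 to compound 3 (2.11 log units; beyond the scatter), a step that the earlier pair could not show, as those two compounds differ in two places. Compound 2 is known only as a limit, so the true size of this step stays unknown and the printed size is only its lower bound: the limit of > 200000 nM in this assay, at which 1 of the 3 values shown sits.

With the fluoro on the fused ring held constant, the other place matters as well: 2,4-difluorophenyl in place of 3,4-difluorophenyl gives a 54-fold higher number from compound 1 to compound 3 (1.73 log units; beyond the scatter), which shows that the fluoro alone does not account for the potency of compound 1.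

The compounds shown give no step for this fluoro in a compound that carries the 3,4-difluorophenyl, so it remains open whether the gain there would be of similar size. Also open, from the compounds shown here alone, is whether a chloro or a methoxy group on the same aromatic carbon would act as the fluoro does.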